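Swapping Methoxycarbonyl for Trifluoromethyl

The source may hold more compounds than are shown below. What is called first, only, known or untested is meant among the compounds shown, and "the series" means these compounds.

Of the compounds shown here, two have so far been tested in a functional assay on MDA-MB-231 cells (Homo sapiens) for inhibition, read by MTT assay, with a stated time of 72 h; a lower number here means a stronger inhibitor, a higher number a weaker inhibitor. Compound 1 `COC(=O)c1ccc(-n2cc(CCCNC(=O)c3ccc(C)cc3)nn2)cc1` gives > 100000 nM, which is a limit of the assay and not a number. Compound 2 `COC(=O)c1ccc(-c2cn(CCCC(=O)Nc3ccc(C)cc3)nn2)cc1` gives 2700 nM. Among the compounds with values here, this is the only true number available, so its standing can't yet be judged against any other measured potency.

The next compound to be measured, compound 3 `Cc1ccc(NC(=O)CCCn2cc(-c3ccc(C(F)(F)F)cc3)nn2)cc1`, differs from compound 2 in one place: trifluoromethyl in place of methoxycarbonyl on an aromatic carbon. Trifluoromethyl takes the place of methoxycarbonyl on an aromatic carbon, para to a large group.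

Within the data shown here, no measured pair shows what this single change does, so any forecast must be cautious and wide. Among the measured compounds shown here, the only anchor is compound 2 at 2700 nM, and a small loss of strength in this assay is expected from that starting point, possibly no larger than the usual scatter. The estimated change is a 1.5-fold higher number from compound 2 to compound 3 (0.17 log units; within the scatter). For compound 3, the expected value is 4000 nM, with an estimated range of 1200 nM to 15000 nM.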

Compound 3, half-maximal inhibitory concentration: 2300 nM
Compound 3: the middle estimate sits 1.7-fold (0.24 log units) above what was measured; low and high end bracket the measured number.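

Replacing methoxycarbonyl with trifluoromethyl on this aromatic carbon, para to a large group, gives a 1.2-fold lower number from compound 2 to compound 3 (0.07 log units; within the scatter), so compound 2 and compound 3 cannot be told apart in this assay. Within the data shown here, this is the first single change that can be read, and it shows that the hydrogen-bond acceptors and the double bond counted on methoxycarbonyl, none of which trifluoromethyl carries, are not required at this position for a value in the range of these two compounds. Nothing measured here explains why the two groups read alike.

Going by these compounds, only these two groups can be compared at this position, so it remains open whether a carboxylic acid, an amine or a plain hydrogen on the same carbon would give a clearly different number. Among these compounds, compound 1 gives > 100000 nM, which is a limit of the assay and not a number, and it differs from the other compounds in more than one place, so no step involving it can be read.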